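Bromo in place of chloro in compound 4

The compounds below may be only part of what the source reports. "The series", "measured", "known", "first", "only" and "open" are said of these compounds alone.

In an ADME assay on THP-1 cells (Homo sapiens) for cytotoxicity, read by flow cytometry and propidium iodide staining, with a stated time of 72 h (a lower number here means a stronger inhibitor, a higher number a weaker inhibitor), compound 3 `Cc1nc(CS(=O)(=O)c2ccc(Cl)cc2)c([N+](=O)[O-])n1CCO` gives 578000 nM, within the scatter of compound 1 `Cc1nc(CS(=O)(=O)c2ccc(Br)cc2)c([N+](=O)[O-])n1C` at 326000 nM and well clear of compound 2 `Cc1ccc(S(=O)(=O)Cc2nc(C)n(CCO)c2[N+](=O)[O-])cc1` at 59000 nM. Compound 4 `Cc1nc(CS(=O)(=O)c2ccc(Br)cc2)c([N+](=O)[O-])n1CCO` differs from compound 3 by bromo in place of chloro on an aromatic carbon. For the measured compounds named here, the one measured step on that carbon is a 9.8-fold higher number from compound 2 to compound 3 (0.99 log units; beyond the scatter), for chloro in place of methyl. Going by the values given here, no measured step isolates bromo against chloro, but compound 1 also carries bromo and gives 326000 nM. No shift beyond the scatter is therefore expected in this assay. The estimated change is a 1.3-fold lower number from compound 3 to compound 4 (0.11 log units; within the scatter). Compound 4 is expected at 450000 nM, with an estimated range of 180000 nM to 1000000 nM.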

Compound 4, half-maximal inhibitory concentration: 124000 nM
Compound 4: middle estimate off by 3.6-fold (0.56 log units), on the high side; measured number outside the range, below it.
By their numbers in this assay, from the lowest: compound 2; then compound 4; then compounds 1 and 3 (each within the scatter of the next).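

In this assay bromo in place of chloro on the aromatic carbon gives a 4.7-fold lower number from compound 3 to compound 4 (0.67 log units; beyond the scatter) so the two halogens are not interchangeable at this position. Against methyl, bromo gives a 2.1-fold higher number from compound 2 to compound 4 (0.32 log units; beyond the scatter) so this carbon separates all three groups, with methyl lowest. Hydroxymethyl in place of hydrogen on the saturated chain carbon bound to an aromatic nitrogen gives a 2.6-fold lower number from compound 1 to compound 4 (0.42 log units; beyond the scatter) and this is the only step shown at that chain carbon.

From the compounds shown here alone, whether that chain step holds with chloro or methyl, and what fluoro or an amine on the aromatic carbon would give, stays open. No evidence at hand explains these shifts.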